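The source may report more compounds than this note shows. Statements on the series, on what has been measured and on what is new or still open speak of the compounds shown alone.

Measured so far in a functional assay on SNU-475 cells (Homo sapiens) for inhibition, read by sulforhodamine B assay, with a stated time of 72 h; on this read-out lower numbers stand for stronger inhibition and higher numbers for weaker inhibition:
- compound 1, `CC(c1ccc(-c2ccccc2)c(F)c1)c1nnc2n1N=C(c1ccc(Cl)cc1)CS2`: 3800 nM
- compound 2, `CC(C)Cc1ccc(C(C)c2nnc3n2N=C(c2ccc(OC(F)(F)F)cc2)CS3)cc1`: 6800 nM
- compound 3, `COc1ccc(C2=Nn3c(nnc3C(C)c3ccc(-c4ccccc4)c(F)c3)SC2)cc1`: 6700 nM

Compound 2 gives the highest of the three numbers, but its gap to compound 3 and its gap to compound 1 both fall within the usual scatter, so the three compounds cannot be separated on these data. Going by the values given here, the only single-point step measured so far is a 1.8-fold higher number from compound 1 to compound 3 (0.25 log units; within the scatter); it concerns the group on the aromatic ring attached to the shared core and changes nothing beyond the scatter.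

Compound 4, `Cc1ccc(C2=Nn3c(nnc3C(C)c3ccc(CC(C)C)cc3)SC2)cc1`, differs from compound 2 in one place: methyl in place of trifluoromethoxy on an aromatic carbon. Among the compounds with values here, no measured pair exchanges a trifluoromethoxy group for a methyl group, so the step from compound 1 to compound 3 is the nearest guide, and it was flat. The substituent at this position therefore has not yet shown an effect on the numbers in this assay, and the expectation for compound 4 is a step of no more than the scatter in either direction.

Estimate for compound 4 in this assay: 5500 nM, expected range 2200 nM to 14000 nM, meaning an expected step of a 1.2-fold lower number from compound 2 to compound 4 (0.09 log units; within the scatter).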

Compound 4, half-maximal inhibitory concentration: 8700 nM
Beside the measured number, compound 4's estimate is 1.6-fold (0.20 log units) below it, within the range that was stated.
By their numbers in this assay, from the lowest: compounds 1, 3, 2 and 4 (each within the scatter of the next, the first and the last beyond it).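

In this assay, methyl in place of trifluoromethoxy on the aromatic carbon gives a 1.3-fold higher number from compound 2 to compound 4 (0.11 log units; within the scatter), so a second exchange at this position stays flat alongside a 1.8-fold higher number from compound 1 to compound 3 (0.25 log units; within the scatter), and it does so with a different group in the other part of the molecule. The new change is also a larger one in what is counted: 5 heavy atoms with 1 hydrogen-bond acceptor leave, and 1 heavy atom with no acceptor enters, yet the two numbers cannot be separated, so neither the size of the group nor the loss of that acceptor has yet shown up as a difference at this position. No measurement at hand bears on why the numbers stay flat here.

Going by these compounds, all four groups seen at this position are small and carry no net charge, so it remains open whether an amine, a carboxylic acid or a longer chain there would give a step beyond the scatter. Going by these compounds alone, the group in the other part of the molecule has no pair differing in that one place, so its contribution cannot be read.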